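Will the Mirror Image of Compound 2 Last as Long?

The source may report more compounds than this note shows. Statements on the series, on what has been measured and on what is new or still open speak of the compounds shown alone.

- compound 1 `CN(CCCNC(=O)Nc1ccc(C(C)(C)C)cc1)C[C@H]1C[C@@H](c2ccc3c(N)ncnn23)[C@H](O)[C@@H]1O`: 0.113 h
- compound 2 `CC(C)NC[C@@H]1C[C@H](c2ccc3c(N)ncnn23)[C@@H](O)[C@H]1O`: 0.422 h

Both compounds were tested in an ADME assay on the whole organism (Mus musculus, strain BALB/c) for metabolic stability, read by LC-MS, with a stated time of 600 min, at a dose of 20 mg/kg by the oral route; on this read-out lower numbers stand for a shorter-lived compound and higher numbers for a longer-lived compound. The longer a compound survives in the animal, the higher its half-life. Compound 2 (0.422 h) holds the higher of the two numbers, and its gap to compound 1 (0.113 h) lies beyond the usual scatter of repeat measurements.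

The next compound is compound 3 `CC(C)NC[C@H]1C[C@@H](c2ccc3c(N)ncnn23)[C@H](O)[C@@H]1O`. The structural change from compound 2 is the two compounds have the same atoms and bonds and differ only in configuration as drawn: 4 of 4 stereo elements differ (all stereocentres are inverted: mirror images); a stereocentre at a saturated ring carbon is drawn S in compound 2 and R in compound 3; a stereocentre at a saturated ring carbon is drawn R in compound 2 and S in compound 3; a stereocentre at a saturated ring carbon is drawn R in compound 2 and S in compound 3; a stereocentre at a saturated ring carbon is drawn S in compound 2 and R in compound 3. The two compounds therefore relate as a left hand does to a right hand, with the same atoms and bonds and all stereocentres inverted.

For the measured compounds named here, no pair of mirror images with measured half-lives is available here, so the data cannot show how much such a change matters in this assay. With no evidence for a direction, the expectation is no step beyond the scatter, and the expected step of a 1.1-fold lower number from compound 2 to compound 3 (0.02 log units; within the scatter) is small. The range is kept wide to reflect this uncertainty. For compound 3 the estimated half-life is 0.4 h, with an expected range from 0.13 h to 1.1 h.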

Compound 3, half-life: 0.748 h
Beside the measured number, compound 3's estimate is 1.9-fold (0.27 log units) below it; the range from low to high includes it.
By their numbers in this assay, from the lowest: compound 1; then compounds 2 and 3 (each within the scatter of the next).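

For the compounds shown here, this is the first pair of mirror images with measured half-lives in this assay, and it gives a 1.8-fold higher number from compound 2 to compound 3 (0.25 log units; within the scatter). Inverting all the stereocentres together therefore produces no change that can be told apart from the ordinary variation between repeat measurements, so this assay does not separate these two mirror images, and neither compound can be said to last longer in the mouse. The comparison is a clean test of handedness alone, with no added or removed group to confuse the reading, because the only structural difference lies here: the fact that compounds 2 and 3 differ only in the configuration as drawn

What this single pair leaves open is whether handedness would remain equally unimportant with a different group on the side-chain nitrogen, such as a cyclopropyl group or a carboxylic acid, and whether repeat measurements would confirm the present reading. It also says nothing about compounds in which only some of the stereocentres are inverted, since such compounds are not mirror images of compound 2 and could behave differently from both members of this pair.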